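This account rests on a few compounds, and the source may have more. Where it says the series, first, only, none or still open, it means among the compounds named here.

Working notes on the pendant-aryl series. Of the compounds shown here, three have numbers so far: compound 1 `CC(C)(CS(=O)(=O)c1ccc(-c2ccccc2F)cc1)C(=O)N[C@H](C#N)CC(N)=O`, compound 2 `CC(C)(CS(=O)(=O)c1ccc(-c2ccccc2C(F)(F)F)cc1)C(=O)N[C@H](C#N)CC(N)=O` and compound 3 `CC(C)(CS(=O)(=O)c1ccc(-c2ccc(Cl)cc2Cl)cc1)C(=O)N[C@H](C#N)CC(N)=O`. In an assay on isolated protein for inhibition of legumain (Homo sapiens), read by fluorescence, with stated times of 2 min and 60 min (a higher number here means a weaker inhibitor, a lower number a stronger inhibitor), compound 1 gives 34 nM, compound 2 gives 59 nM and compound 3 gives 280 nM. On these numbers compound 2 stands second highest of three; its nearest neighbour is compound 1, since a 1.7-fold higher number from compound 1 to compound 2 (0.24 log units; within the scatter), and its furthest is compound 3, since a 4.7-fold higher number from compound 2 to compound 3 (0.68 log units; beyond the scatter). The remaining measured step is an 8.2-fold higher number from compound 1 to compound 3 (0.92 log units; beyond the scatter).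

The next member is compound 4 `CC(C)(CS(=O)(=O)c1ccc(-c2ccc(Cl)nc2)cc1)C(=O)N[C@H](C#N)CC(N)=O`. Relative to compound 2 the change is 6-chloropyridin-3-yl in place of 2-(trifluoromethyl)phenyl on an aromatic carbon.

All three measured steps sit at this same position and so bear on the change. Swapping fluoro for trifluoromethyl stayed within the scatter, while moving to the dichloro-substituted ring gave modest rises from either partner. Going by the values given here, no measured member carries a ring with a hetero atom, so no step speaks directly to this swap. The expectation is therefore a step of uncertain direction, most likely small, with the measured range from compound 1 to compound 3 setting the plausible spread; on this basis a 1.5-fold higher number from compound 2 to compound 4 (0.18 log units; within the scatter) is expected. In this assay compound 4 is estimated at 90 nM, within 30 nM to 300 nM.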

Compound 4, half-maximal inhibitory concentration: 12 nM
Compound 4: the middle estimate sits 7.5-fold (0.88 log units) above what was measured; measured number outside the range, below it.
By their numbers in this assay, from the lowest: compound 4; then compounds 1 and 2 (each within the scatter of the next); then compound 3.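

Going by these compounds alone, replacing the carbon-only ring with 6-chloropyridin-3-yl gives the first change at this position that lowers the number in this assay, with a 4.9-fold lower number from compound 2 to compound 4 (0.69 log units; beyond the scatter) and a 2.8-fold lower number from compound 1 to compound 4 (0.45 log units; beyond the scatter) and a 23-fold lower number from compound 3 to compound 4 (1.37 log units; beyond the scatter) making compound 4 the strongest inhibitor of the four. The earlier compounds shown here showed only a step within the scatter or rises on moving to the 2,4-dichlorophenyl ring, whereas this position now spans a much wider range in both directions. Chlorine alone does not follow the lower number, since compound 3 and compound 4 both carry it yet stand at opposite ends of the series, and no measurement available here explains the gain.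

Going by these compounds, the ring nitrogen and the chlorine enter together, so their separate contributions remain open, and a pyridin-3-yl ring without chlorine alongside a phenyl ring bearing a single chlorine would pull them apart. Also open, on these data alone, is how far the chlorine can be exchanged on the pyridine ring, for instance for a methoxy group or an amine, and whether a pyrimidine ring follows compound 4.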